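Neopentyl for tert-butyl in two cores: microsomal clearance notes

The source may hold more compounds than are shown below. What is called first, only, known or untested is meant among the compounds shown, and "the series" means these compounds.

Measured so far in an ADME assay on liver for metabolic stability, with Liver microsome (Homo sapiens) as the target, read by LC-MS, using microsomes; a lower number here means slower removal, a higher number faster removal of the compound:

- compound 1 `CC(C)(C)[C@@H](O)C(=O)N1[C@H](C(=O)NCc2cc(Cl)ccc2-n2cnnn2)C[C@@H]2C[C@@H]21`: 75 mL.min-1.g-1
- compound 2 `CC(C)(C)[C@@H](O)C(=O)N1NCC[C@H]1C(=O)NCc1cc(Cl)ccc1-n1cnnn1`: 15 mL.min-1.g-1
- compound 3 `CC(C)(C)C[C@@H](O)C(=O)N1[C@H](C(=O)NCc2cc(Cl)ccc2-n2cnnn2)C[C@@H]2C[C@@H]21`: 40 mL.min-1.g-1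

Compounds 1 and 3 share a core and differ only by neopentyl in place of tert-butyl on a saturated chain carbon bound to a carbonyl carbon and an oxygen on a saturated carbon. That change gives a 1.9-fold lower number from compound 1 to compound 3 (0.27 log units; within the scatter), so the two numbers are not told apart here.

Compound 2 carries a different core; how the two cores differ is not broken down here. In this assay compound 2 gives the lowest number of the three, and its gaps to compound 3 and to compound 1 both lie beyond the scatter.

Compound 4 `CC(C)(C)C[C@@H](O)C(=O)N1NCC[C@H]1C(=O)NCc1cc(Cl)ccc1-n1cnnn1` is not yet measured. It is made from compound 2 by neopentyl in place of tert-butyl on a saturated chain carbon bound to a carbonyl carbon and an oxygen on a saturated carbon, the same change as from compound 1 to compound 3, at the same place. The step is expected to be a 1.5-fold lower number from compound 2 to compound 4 (0.18 log units; within the scatter), resting on the earlier result a 1.9-fold lower number from compound 1 to compound 3 (0.27 log units; within the scatter), that is, small and within the scatter. On that basis compound 4 is estimated at 10 mL.min-1.g-1 in this assay, with a likely range from 5 mL.min-1.g-1 to 22 mL.min-1.g-1.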

Compound 4, intrinsic clearance in microsomes: 25 mL.min-1.g-1
Compound 4: middle estimate off by 2.5-fold (0.40 log units), on the low side; measured number outside the range, above it.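

In this assay, neopentyl in place of tert-butyl on a saturated chain carbon bound to a carbonyl carbon and an oxygen on a saturated carbon gives a 1.7-fold higher number from compound 2 to compound 4 (0.22 log units; within the scatter), so this step alone does not tell the two numbers apart. Each step is within the scatter on its own, yet the two do not agree when set side by side: the same change on two cores in this assay, a 1.9-fold lower number (0.27 log units; within the scatter) from compound 1 to compound 3 and a 1.7-fold higher number (0.22 log units; within the scatter) from compound 2 to compound 4, 3.1-fold (0.49 log units) apart, beyond the scatter of two such steps The step measured on one core therefore did not carry over to the other in this pair, but two cores cannot show how the change behaves across the series, and the data do not say which feature of the cores lies behind the gap.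

Only tert-butyl and neopentyl stand at this place, so a third core remains the direct test of whether the change follows any rule. Also open, on these data alone, is how a longer chain, an amine or a carboxylic acid at the same place would read in this assay on either core.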